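Aryl Variation at the Amine-Bound Methylene: Compound 4

This account rests on a few compounds, and the source may have more. Where it says the series, first, only, none or still open, it means among the compounds named here.

Measured compounds:
compound 1 `C=C1CC[C@@H]2[C@](C)(CNCc3ccc(OC)c(OC)c3)[C@H](O)CC[C@@]2(C)[C@@H]1/C=C/C1=CCOC1=O`: 3740 nM
compound 2 `C=C1CC[C@@H]2[C@](C)(CNCc3ccc([N+](=O)[O-])cc3)[C@H](O)CC[C@@]2(C)[C@@H]1/C=C/C1=CCOC1=O`: 1340 nM
compound 3 `C=C1CC[C@@H]2[C@](C)(CNCc3ccncc3)[C@H](O)CC[C@@]2(C)[C@@H]1/C=C/C1=CCOC1=O`: 2030 nM

All three numbers come from a functional assay on BMMC cells (Mus musculus, strain C57BL/6) for inhibition, with stated times of 5 days and 48 h; a higher number here means a weaker inhibitor, a lower number a stronger inhibitor. Compound 3 stands second highest of the three: its nearest neighbour is compound 2, its step of a 1.5-fold higher number from compound 2 to compound 3 (0.18 log units; within the scatter), and the furthest is compound 1, with a 1.8-fold lower number from compound 1 to compound 3 (0.27 log units; within the scatter); neither separation is beyond the scatter. Only compound 2 against compound 1, a 2.8-fold lower number from compound 1 to compound 2 (0.45 log units; beyond the scatter), is a step of note, and it does not involve compound 3.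

Compound 4 `C=C1CC[C@@H]2[C@](C)(CNCc3ccco3)[C@H](O)CC[C@@]2(C)[C@@H]1/C=C/C1=CCOC1=O` differs from compound 3 in one place: furan-2-yl in place of pyridin-4-yl on a saturated chain carbon bound to an amine nitrogen. Among the compounds with values here, the steps that bear on this are the two that bring pyridin-4-yl into the same place, a 1.8-fold lower number from compound 1 to compound 3 (0.27 log units; within the scatter) and a 1.5-fold higher number from compound 2 to compound 3 (0.18 log units; within the scatter), both within the scatter, so aryl exchange at this position has so far moved this assay little. Within the data shown here, no measured step introduces furan-2-yl. The expected step is therefore a 1.1-fold higher number from compound 3 to compound 4 (0.03 log units; within the scatter), with no direction beyond the scatter anticipated. For compound 4 the estimate in this assay is 2200 nM, expected to fall between 900 nM and 5500 nM.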

Compound 4, half-maximal inhibitory concentration: 1830 nM
Compound 4: the middle estimate sits 1.2-fold (0.08 log units) above what was measured; low and high end bracket the measured number.
By their numbers in this assay, from the lowest: compounds 2, 4, 3 and 1 (each within the scatter of the next, the first and the last beyond it).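

In this assay, the first five-membered aromatic ring at this position, on a saturated chain carbon bound to an amine nitrogen, gives a step that stays within the scatter against pyridin-4-yl: a 1.1-fold lower number from compound 3 to compound 4 (0.05 log units; within the scatter). Against 4-nitrophenyl the result is the same, a 1.4-fold higher number from compound 2 to compound 4 (0.14 log units; within the scatter), so furan-2-yl, pyridin-4-yl and 4-nitrophenyl cannot be told apart pairwise here, and ring size does not separate the first two. Furan-2-yl does stand apart from 3,4-dimethoxyphenyl in a modest step, a 2.0-fold lower number from compound 1 to compound 4 (0.31 log units; beyond the scatter), although pyridin-4-yl remains within the scatter of that group.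

No supporting data bear on why these steps take this size. From the compounds shown here alone, whether a non-aromatic cyclohexyl group or a plain alkyl chain in place of the aromatic ring would hold the number in this range stays open.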